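The compounds below may be only part of what the source reports. "The series", "measured", "known", "first", "only" and "open" are said of these compounds alone.

In an assay on isolated protein for inhibition of kinesin heavy chain isoform 5A (Homo sapiens) (a higher number here means a weaker inhibitor, a lower number a stronger inhibitor), three compounds built on one shared core have been tested, and every one of them sits at the limit of the assay rather than at a measured number. Compound 1 `COc1ccc(Nc2nc3cc(C(N)=O)ccc3n2Cc2ccccc2C(F)(F)F)cc1F` gives > 50000 nM, which is a limit and not a value. Compound 2 `COC(=O)c1ccc2c(c1)nc(Nc1ccc(S(N)(=O)=O)cc1)n2Cc1ccccc1C(F)(F)F` gives > 50000 nM, again only a limit. Compound 3 `CNC(=O)c1ccc2c(c1)nc(Nc1ccc(S(N)(=O)=O)cc1)n2Cc1ccccc1C(F)(F)F` gives > 50000 nM, also a limit. Among the compounds with values here, the single step in which only one place changes, a step that the two limits leave unreadable from compound 2 to compound 3, therefore cannot be read in size or direction because of the limit of > 50000 nM in this assay, at which 3 of the 3 values shown sit.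

Compound 4 `NS(=O)(=O)c1ccc(Nc2nc3cc(C(=O)N4CCCC4)ccc3n2Cc2ccccc2C(F)(F)F)cc1` differs from compound 3 in one place: pyrrolidin-1-yl in place of methylamino on a carbonyl carbon. Within the data shown here, no measured step bears on this change, since every value so far is a limit, and nothing about where compound 3 stands can be said beyond that it is at the limit. The step of a number no higher from compound 3 to compound 4 (the limit leaves the size open) is therefore expected to be unreadable, most likely ending at the limit once more. Compound 4 is expected to give about 50000 nM, within a range from 15000 nM to 150000 nM.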

Compound 4, half-maximal inhibitory concentration: > 50000 nM
Compound 4 ended at the assay's limit; the forecaster's own chance of this, stated with the estimate: 85%; the middle value lies on the limit itself.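

Neither the step from compound 3 to compound 4 nor the step from compound 2 to compound 4 can be read in size or direction, because each result is a limit and not a number: (the limit of > 50000 nM in this assay, at which 4 of the 4 values shown sit). The compounds shown leave open how strongly any of them inhibits in this assay and whether changing the group on the carbonyl carbon matters at all.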